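Cyclopropane hydrazides on OE21 cells: step to a prenyl ether

A few compounds are considered here, and "the series" means these few. Any claim that something is new, unique, unknown or untested is made for them only; others in the source may bear on it.

Working notes on a small set of cyclopropane carbohydrazides. Compound 1 `CCOc1ccc(C2CC2C(=O)NNC(=O)c2ccncc2)cc1` and compound 3 `CC(C)=CCC/C(C)=C/COc1ccc(C2CC2C(=O)NNC(=O)c2ccncc2)cc1` carry the shared core with a pyridine-derived hydrazide end; in a functional assay on OE21 cells (Homo sapiens) for inhibition, read by MTT assay, with a stated time of 72 h (on this read-out lower numbers stand for stronger inhibition and higher numbers for weaker inhibition), compound 1 gives "not determined" (no result reported) and compound 3 gives "not determined" (no result reported), so neither contributes a number. For the measured compounds named here, compound 2 `O=C(NNc1nncc2ccccc12)C1CC1c1ccc(OC(F)(F)F)cc1` is the only member with a numerical result: in this assay compound 2 gives 42000 nM, a weak figure and, with nothing else measured, the sole reference point of the set.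

Compound 4 `CC(C)=CCOc1ccc(C2CC2C(=O)NNc2nncc3ccccc23)cc1` keeps the core of compound 2 and differs from it at one place only: 3-methylbut-2-en-1-yl in place of trifluoromethyl on an oxygen on an aromatic ring. Going by the values given here, no measured pair shows the effect of such an exchange on the aryl ether, so the expected step from compound 2 to compound 4 in this assay is a 1.2-fold lower number from compound 2 to compound 4 (0.08 log units; within the scatter), which is not beyond the usual scatter in either direction. On that basis compound 4 is expected to give about 35000 nM in this assay, with a plausible range from 12000 nM to 100000 nM.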

Compound 4, half-maximal inhibitory concentration: 38000 nM
Compound 4: middle estimate off by 1.1-fold (0.04 log units), on the low side; low and high end bracket the measured number.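

In this assay, the first pair read at this position gives a 1.1-fold lower number from compound 2 to compound 4 (0.04 log units; within the scatter) for 3-methylbut-2-en-1-yl in place of trifluoromethyl on an oxygen on an aromatic ring. The position therefore accepts a chain of carbon atoms with a double bond in place of the fluorinated group, with no change in the read-out beyond the scatter, and the pair stays in the same weak range. Nothing at hand bears on why the two compounds read alike.

From the compounds shown here alone, with a single pair, it remains open whether this insensitivity holds for other groups on that oxygen, such as a chain ending in an amine or a carboxylic acid. Going by these compounds, it is also open whether a hydroxyl group directly on the aromatic ring would read any differently.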